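Capping the Carbamoyl Nitrogen of Compound 2

This account rests on a few compounds, and the source may have more. Where it says the series, first, only, none or still open, it means among the compounds named here.

In a functional assay on MOLM-13 cells (Homo sapiens) for antiproliferative activity (on this read-out higher numbers stand for weaker inhibition and lower numbers for stronger inhibition), compound 1 (`Cc1c(-c2ccc(-c3ccccc3F)cc2)nc2ccc(F)cc2c1-c1nnn[nH]1`) reads > 3000 nM as a limit of the assay and not a number. Among the compounds with values here, compound 2 (`Cc1c(-c2ccc(-c3ccccc3F)cc2)nc2ccc(F)cc2c1C(N)=O`) gives 128 nM in this assay and so holds the only true number so far. Within the data shown here, the one measured step that touches its carbamoyl is an at least 23-fold lower number from compound 1 to compound 2 (1.36 log units; beyond the scatter) and it is large, though one end of it rests on the limit of > 3000 nM in this assay, at which 1 of the 2 values shown sits, and not on a number. Compound 3 (`COC(=O)NC(=O)c1c(C)c(-c2ccc(-c3ccccc3F)cc2)nc2ccc(F)cc12`) puts methoxycarbonyl in place of hydrogen on an amide-type nitrogen of that same carbamoyl. Among the measured compounds shown here, no measured step makes this exact change. With only an at least 23-fold lower number from compound 1 to compound 2 (1.36 log units; beyond the scatter) as a guide, a moderate step toward weaker inhibition is expected. The expected change is a 3.1-fold higher number from compound 2 to compound 3 (0.49 log units; beyond the scatter) in this assay as an estimate. For compound 3 the estimated value is 400 nM with 100 nM to 1800 nM as the expected span.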

Compound 3, half-maximal inhibitory concentration: 403 nM
Compound 3: the middle estimate sits 1.0-fold (0.00 log units) below what was measured; measured number inside the range.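

Putting methoxycarbonyl on the amide-type nitrogen weakens inhibition only modestly in this assay, with a 3.1-fold higher number from compound 2 to compound 3 (0.50 log units; beyond the scatter), so one amide hydrogen of the carbamoyl can be replaced and the compound still acts on these cells, which the earlier pair, differing in the whole group on the aromatic carbon, could not show. The capped carbamoyl also keeps a clear lead over 1H-tetrazol-5-yl, with an at least 7.4-fold lower number from compound 1 to compound 3 (0.87 log units; beyond the scatter). Compound 1 reads > 3000 nM, a limit of the assay and not a number, so this second step gives only a bound: the limit of > 3000 nM in this assay, at which 1 of the 3 values shown sits.

On these data alone, whether a smaller group such as acetyl or methyl on the same nitrogen would read closer to compound 2 stays open. So does how a carboxylic acid in place of the whole carbamoyl would read.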